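Adding a hydroxy group to compound 2

The compounds below may be only part of what the source reports. "The series", "measured", "known", "first", "only" and "open" are said of these compounds alone.

compound 1 `CC(=O)Nc1ccc2oc(-c3ccc(F)cc3)cc(=O)c2c1`: 22000 nM
compound 2 `Nc1ccc2oc(-c3ccc(F)cc3)cc(=O)c2c1`: 10000 nM

In an ADME assay on THP-1 cells (Homo sapiens) for cytotoxicity, read by flow cytometry and propidium iodide staining, with a stated time of 72 h (on this read-out higher numbers stand for weaker inhibition and lower numbers for stronger inhibition), compound 2 gives 10000 nM, the lowest of the two numbers. Among the measured compounds shown here, the only measured step is a 2.2-fold lower number from compound 1 to compound 2 (0.34 log units; beyond the scatter). That change lies on the nitrogen, so it bears only loosely on the next one. Compound 3 `Nc1ccc2oc(-c3ccc(F)cc3)c(O)c(=O)c2c1` differs from compound 2 by hydroxy in place of hydrogen on an aromatic carbon. For the measured compounds named here, no measured step covers this change, so no step beyond the scatter is expected. The estimated step is a 1.3-fold lower number from compound 2 to compound 3 (0.10 log units; within the scatter). The expected value for compound 3 is 8000 nM, with an estimated range of 3000 nM to 20000 nM.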

Compound 3, half-maximal inhibitory concentration: 4000 nM
For compound 3 the middle estimate is 2.0-fold (0.30 log units) above the measured one; measured number inside the range.
By their numbers in this assay, from the lowest: compound 3; then compound 2; then compound 1.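

In this assay, hydroxy in place of hydrogen on the aromatic carbon two atoms from the ring oxygen gives a 2.5-fold lower number from compound 2 to compound 3 (0.40 log units; beyond the scatter) and a step beyond the scatter, though a modest one. This shows that the number responds to a change on the core itself, not only on the nitrogen, and the direction matches that of the earlier step. Nothing shown accounts for this step. From the compounds shown here alone, whether methoxy or an amine at this position would act like hydroxy remains open. So does whether the step would persist with the acetyl on the nitrogen.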